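This account rests on a few compounds, and the source may have more. Where it says the series, first, only, none or still open, it means among the compounds named here.

Measured so far in an assay on HEK293 cells for activation of Kir3.1/Kir3.2 (Homo sapiens), read by thallium flux; a higher number here means that more compound is needed for the effect, a lower number that less compound is needed:

compound 1, `Cc1cc(NC(=O)Cn2nnc(-c3ccccc3)n2)n(C2CCCCC2)n1`: 96 nM
compound 2, `Cc1cc(NC(=O)Cn2nnc(-c3ccccc3)n2)n(C2CCCC2)n1`: 163 nM
compound 3, `Cc1cc(NC(=O)Cn2nnc(-c3ccccc3)n2)n(-c2ccccc2)n1`: 3020 nM

Compound 1 stands at the lowest of the three numbers in this assay. Compound 2 sits within the scatter of it: a 1.7-fold higher number from compound 1 to compound 2 (0.23 log units; within the scatter). Compound 3 lies well apart: a 31-fold higher number from compound 1 to compound 3 (1.50 log units; beyond the scatter), and likewise a 19-fold higher number from compound 2 to compound 3 (1.27 log units; beyond the scatter). Every one of these steps concerns the group on the aromatic nitrogen of the shared core; the other end of the molecule is the same in all three.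

Compound 4, `Cc1cc(NC(=O)Cn2nnc(-c3cccc(F)n3)n2)n(C2CCCCC2)n1`, keeps the cyclohexyl of compound 1 and changes the other end instead: 6-fluoropyridin-2-yl in place of phenyl on an aromatic carbon. Within the data shown here, no measured step touches this position, so none of the three steps bears directly on the change; they say only that this assay responds strongly to what sits on the aromatic nitrogen. Among the measured compounds shown here, with no comparable step to lean on, the expectation for compound 4 is a step within the scatter, a 1.3-fold higher number from compound 1 to compound 4 (0.10 log units; within the scatter), with a wide margin for the unknown. The estimate for compound 4 in this assay is 120 nM, expected to fall between 40 nM and 400 nM.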

Compound 4, half-maximal effective concentration: > 3000 nM
Compound 4 was reported as a limit (the forecaster's own chance of this, stated with the estimate: 5%); at least 25-fold (1.39 log units) between middle value and limit.
By their numbers in this assay, from the lowest: compounds 1 and 2 (each within the scatter of the next); then compound 3.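

Compound 4 carries a limit and not a number in this assay: the limit of > 3000 nM in this assay, at which 1 of the 4 values shown sits. Even so, the step can be read as a lower bound: 6-fluoropyridin-2-yl in place of phenyl on the aromatic carbon gives an at least 31-fold higher number from compound 1 to compound 4 (1.49 log units; beyond the scatter). The cyclohexyl on the aromatic nitrogen stays the same across this step, so the large change belongs to this end of the molecule alone, which shows that this assay responds to the group on the aromatic carbon and not only to the group on the aromatic nitrogen.

The entering group brings in a ring nitrogen and a fluorine together, and the compounds shown do not separate the two; a plain pyridine ring without the fluorine and a fluorophenyl ring would each isolate one of them. Also open, as far as these compounds go, are how far the true number of compound 4 lies past its limit, whether a methyl or methoxy group on the phenyl ring is accepted at this end, and whether the same step holds with cyclopentyl on the aromatic nitrogen.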